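From Chloro to Nitro: An Unmeasured Step

The source may report more compounds than this note shows. Statements on the series, on what has been measured and on what is new or still open speak of the compounds shown alone.

Measured so far in a functional assay on P388 cells (Mus musculus) for antiproliferative activity, read by colorimetric assay and MTT assay; on this read-out lower numbers stand for stronger inhibition and higher numbers for weaker inhibition:
compound 1 `O=S(=O)(Nc1cccc2cc[nH]c12)c1ccc(Cl)cc1`: 6 ug/mL
compound 2 `O=S(=O)(Nc1cc(Cl)cc2cc[nH]c12)c1ccc(Cl)cc1`: 9.9 ug/mL

The two values lie within the scatter of each other, so compound 2 cannot be ranked against compound 1. Among the measured compounds shown here, the only measured step is a 1.7-fold higher number from compound 1 to compound 2 (0.22 log units; within the scatter), and it places chloro on an aromatic carbon where hydrogen stood.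

Compound 3 `O=[N+]([O-])c1ccc(S(=O)(=O)Nc2cc(Cl)cc3cc[nH]c23)cc1` awaits measurement. It differs from compound 2 by nitro in place of chloro on an aromatic carbon. This is nitro in place of chloro on an aromatic carbon, para to a large group. For the measured compounds named here, no measured step touches that place, and the one step available gives no direction. No step beyond the scatter is therefore expected in this assay, and compound 2 at 9.9 ug/mL serves as the anchor. The expected change is a 1.2-fold lower number from compound 2 to compound 3 (0.09 log units; within the scatter). For compound 3 the estimated value is 8 ug/mL, with an expected range of 3 ug/mL to 20 ug/mL.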

Compound 3, half-maximal inhibitory concentration: 13 ug/mL
Compound 3: the middle estimate sits 1.6-fold (0.21 log units) below what was measured; low and high end bracket the measured number.
By their numbers in this assay, from the lowest: compounds 1, 2 and 3 (each within the scatter of the next, the first and the last beyond it).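

In this assay, nitro in place of chloro on an aromatic carbon, para to a large group, gives a 1.3-fold higher number from compound 2 to compound 3 (0.12 log units; within the scatter) and so adds a measured change at a place the earlier step did not touch. The two groups differ in their atoms and in their hydrogen-bond acceptors, yet this exchange does not move the number beyond the scatter. No measurement at hand explains the result or gives a property of either group.

The compounds shown leave open whether another group at this position, such as an amine or a carboxylic acid, would give a number beyond the scatter of compound 2. They also leave open whether nitro at this position would give a comparable step on the core of compound 1, which lacks the chloro of compound 2.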